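The source may hold more compounds than are shown below. What is called first, only, known or untested is meant among the compounds shown, and "the series" means these compounds.

In a functional assay on MCF7 cells (Homo sapiens) for cytotoxicity, read by MTT assay, with a stated time of 4 h (on this read-out higher numbers stand for weaker inhibition and lower numbers for stronger inhibition), compound 1 (`COC(=O)C1=CO[C@@H](O[C@@H]2O[C@H](CO)[C@@H](OC(C)=O)[C@H](OC(C)=O)[C@H]2OC(C)=O)[C@@H]2[C@@H](C)[C@@H](OC(C)=O)C[C@H]12`) gives "not active" (no number reported), and no number is reported for it. Compound 2 (`CCC(=O)OC[C@H]1O[C@@H](O[C@@H]2OC=C(C(=O)OC)[C@H]3C[C@H](OC(C)=O)[C@H](C)[C@@H]23)[C@H](OC(C)=O)[C@@H](OC(C)=O)[C@@H]1OC(C)=O`) gives 1.88 ug/mL. Compound 3 (`CCCCCCCCCCCC(=O)OC[C@H]1O[C@@H](O[C@@H]2OC=C(C(=O)OC)[C@H]3C[C@H](OC(C)=O)[C@H](C)[C@@H]23)[C@H](OC(C)=O)[C@@H](OC(C)=O)[C@@H]1OC(C)=O`) gives 0.24 ug/mL, the lower of the two numbers available, which places it at the strong end of this small set.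

Compound 4 (`C=CC(=O)OC[C@H]1O[C@@H](O[C@@H]2OC=C(C(=O)OC)[C@H]3C[C@H](OC(C)=O)[C@H](C)[C@@H]23)[C@H](OC(C)=O)[C@@H](OC(C)=O)[C@@H]1OC(C)=O`) has not yet been measured. It departs from compound 3 with vinyl in place of undecyl on a carbonyl carbon.

Within the data shown here, only one measured step bears on this change. It is a 7.8-fold lower number from compound 2 to compound 3 (0.89 log units; beyond the scatter), in which the acyl chain grows by nonyl in place of hydrogen. Compound 4 goes back the other way, to a short chain much like that of compound 2, so a step of similar size is expected in the opposite direction, towards weaker inhibition. Among the measured compounds shown here, the double bond of vinyl has no measured precedent in this set, so the range is kept wide, and a result without a number, as for compound 1, remains possible.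

The expected change is a 7.5-fold higher number from compound 3 to compound 4 (0.88 log units; beyond the scatter). Compound 4 is estimated at 1.8 ug/mL, with an expected range from 0.5 ug/mL to 6 ug/mL.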

Compound 4, half-maximal inhibitory concentration: "not active" (no number reported)
No number was reported for compound 4, and the estimate cannot be compared.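

In this assay, among these compounds, compound 4 gives "not active" (no number reported) and, with no number to set against compound 3, no step between the two can be read. Nothing measured here offers an explanation for this result. The compounds shown leave open how vinyl compares with undecyl on this read-out when expressed as a number.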